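Vinyl in place of pentyl: an expected small step

A few compounds are considered here, and "the series" means these few. Any claim that something is new, unique, unknown or untested is made for them only; others in the source may bear on it.

Measured so far:
- Compound 1 `CCCCCCCC/C=C\CCCCCCCC(=O)Nc1nnc(S[C@@H]2O[C@H](CO)[C@H](O)[C@H](O)[C@H]2O)s1`: 43600 nM
- Compound 2 `CCCCCCCCCCCCCCCC(=O)Nc1nnc(S[C@@H]2O[C@H](CO)[C@H](O)[C@H](O)[C@H]2O)s1`: 62300 nM
- Compound 3 `CCCCCCCCCCCCCC(=O)Nc1nnc(S[C@@H]2O[C@H](CO)[C@H](O)[C@H](O)[C@H]2O)s1`: 33300 nM

All three values come from a functional assay on MDA-MB-231 cells (Homo sapiens) for cytotoxicity, read by MTT assay, with a stated time of 24 h; on this read-out lower numbers stand for stronger inhibition and higher numbers for weaker inhibition. Compound 3, at 33300 nM, cannot be separated from the other two, as a 1.3-fold lower number from compound 1 to compound 3 (0.12 log units; within the scatter) and a 1.9-fold lower number from compound 2 to compound 3 (0.27 log units; within the scatter) show.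

The next compound is compound 4 `C=CCCCCCCCCC(=O)Nc1nnc(S[C@@H]2O[C@H](CO)[C@H](O)[C@H](O)[C@H]2O)s1`, which carries vinyl in place of pentyl on a saturated chain carbon, eight bonds along the chain from a carbonyl carbon.

The nearest evidence comes from the other chain changes. Removing ethyl gave a 1.9-fold lower number from compound 2 to compound 3 (0.27 log units; within the scatter), and replacing dec-1-en-1-yl with octyl gave a 1.4-fold higher number from compound 1 to compound 2 (0.16 log units; within the scatter). Neither step leaves the scatter in this assay. Among the measured compounds shown here, no measured compound carries vinyl at this place, so the evidence is indirect.

An estimated 1.2-fold higher number from compound 3 to compound 4 (0.08 log units; within the scatter) is therefore expected, with no change beyond the scatter. Compound 4 is expected at 40000 nM, with an estimated range of 18000 nM to 90000 nM.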

Compound 4, half-maximal inhibitory concentration: 80600 nM
Compound 4: the middle estimate sits 2.0-fold (0.30 log units) below what was measured; low and high end bracket the measured number.
By their numbers in this assay, from the lowest: compounds 3, 1, 2 and 4 (each within the scatter of the next, the first and the last beyond it).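

In this assay, vinyl in place of pentyl on a saturated chain carbon, eight bonds along the chain from a carbonyl carbon, gives the first step among these compounds to leave the scatter (a 2.4-fold higher number from compound 3 to compound 4 (0.38 log units; beyond the scatter)), so the read-out at this place is not indifferent to every chain change. That holds only against compound 3, since the other two comparisons stay within the scatter (a 1.3-fold higher number from compound 2 to compound 4 (0.11 log units; within the scatter); a 1.8-fold higher number from compound 1 to compound 4 (0.27 log units; within the scatter)) and leave compound 4 inseparable from compound 1 and compound 2. Nothing available on these compounds bears on why the number moved.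

The compounds shown leave open whether the step belongs to the double bond of the vinyl or to the smaller group, a question that ethyl at this place would address. Going by these compounds, how an amine or a carboxylic acid in place of vinyl would read in this assay also stays open.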